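This account rests on a few compounds, and the source may have more. Where it says the series, first, only, none or still open, it means among the compounds named here.

In an ADME assay on U2OS cells (Homo sapiens) for cytotoxicity (a lower number here means that less compound is tolerated, a higher number that more compound is tolerated), compound 1 (`CCCCCCCCc1ccc(C(=O)N/N=C/c2ccc([N+](=O)[O-])o2)cc1`) reads > 200000 nM as a limit of the assay, not a number. Compound 1 therefore stands at the limit of > 200000 nM in this assay, at which 1 of the 2 values shown sits, and offers no exact starting point. Among the measured compounds shown here, compound 2 (`O=C(N/N=C/c1ccc([N+](=O)[O-])o1)C1CCCCC1`) gives 25400 nM as the only exact number so far. That number lies on the lower side of the limit of compound 1. For the measured compounds named here, no measured pair differs in one place alone, so no measured step is available as a guide.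

The next compound, compound 3 (`N#Cc1ccc(C(=O)N/N=C/c2ccc([N+](=O)[O-])o2)cc1`), has cyano in place of octyl on an aromatic carbon, para to a large group: cyano in place of octyl on an aromatic carbon on the core of compound 1.

The expected change is a move to a lower number in this assay beyond the scatter, with less compound tolerated. The estimated step of an at least 6.6-fold lower number from compound 1 to compound 3 (0.82 log units; beyond the scatter) is only loosely bounded. This expectation leans on compound 2 at 25400 nM as a compound without the octyl chain, and one compound is thin support. For compound 3 the estimated value is 30000 nM with an expected range from 8000 nM to 130000 nM in this read-out.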

Compound 3, half-maximal cytotoxic concentration: 21400 nM
The estimate for compound 3 lay 1.4-fold (0.15 log units) above the measured number; low and high end bracket the measured number.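

In this assay, the aromatic carbon para to a large group now carries its first measured change: cyano in place of octyl gives an at least 9.3-fold lower number from compound 1 to compound 3 (0.97 log units; beyond the scatter). Among the compounds shown here, until now no pair differed in one place alone, so the direction of a change at this position was unknown; it is now known for this one exchange, and the step lies beyond the scatter. Its full size remains unknown, since the compound 1 end of the step is a limit of the assay and not a number: the limit of > 200000 nM in this assay, at which 1 of the 3 values shown sits.

On these data alone, a single pair cannot separate the loss of the octyl chain from the arrival of the cyano group, so it remains open whether a shorter alkyl chain, a methoxy group or an amine at this position would read nearer compound 1 or compound 3. Also open, as far as these compounds go, is whether a carboxylic acid in the same place would follow the same direction, and whether the step would carry over to a core other than that of compound 1.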